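A few compounds are considered here, and "the series" means these few. Any claim that something is new, unique, unknown or untested is made for them only; others in the source may bear on it.

Among the compounds with values here, compound 2 `Cc1ccc(C(C)NC(=O)/N=C(\N)NCCCc2sc(N)nc2C)cc1` gives 30.9 nM in an assay on membranes from Sf9 cells for displacement of a labelled ligand from histamine H2 receptor (Homo sapiens), read by scintillation counting, with a stated time of 60 min (a lower number here means a stronger inhibitor, a higher number a weaker inhibitor), the lowest of the three numbers measured so far. Compound 1 `Cc1nc(N)sc1CCCN/C(N)=N/C(=O)NC(C)c1ccc(OC(F)(F)F)cc1` gives 126 nM in this assay. Compound 3 `CCCCCCNC(=O)/N=C(\N)NC1CCc2nc(N)sc2C1` differs from compound 2 in several groups at once; in this assay compound 3 gives 1120 nM. Within the data shown here, the only one-place step among the measured compounds is a 4.1-fold lower number from compound 1 to compound 2 (0.61 log units; beyond the scatter), a modest change beyond the scatter from exchanging one group on the aromatic ring for another. Compound 4 `Cc1nc(N)sc1CCCN/C(N)=N/C(=O)NC(C)c1cccc(F)c1` carries 3-fluorophenyl in place of 4-methylphenyl on a saturated chain carbon bound to an amide-type nitrogen and a saturated chain carbon. Among the measured compounds shown here, no measured step exchanges 4-methylphenyl for 3-fluorophenyl, so the comparison that bears on it is a 4.1-fold lower number from compound 1 to compound 2 (0.61 log units; beyond the scatter), which shows that a change of this kind on this ring is enough to move the number beyond the scatter, while the direction for the present change has no direct precedent. A modest rise beyond the scatter is expected, a 2.1-fold higher number from compound 2 to compound 4 (0.32 log units; beyond the scatter), with the direction held loosely. The estimate for compound 4 in this assay is 65 nM, with a range from 25 nM to 170 nM.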

Compound 4, inhibition constant: 2.04 nM
Beside the measured number, compound 4's estimate is 32-fold (1.50 log units) above it; measured number outside the range, below it.
By their numbers in this assay, from the lowest: compound 4; then compound 2; then compound 1; then compound 3.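

In this assay, exchanging 4-methylphenyl for 3-fluorophenyl on this saturated chain carbon gives a 15-fold lower number from compound 2 to compound 4 (1.18 log units; beyond the scatter), a large step where the earlier exchange on the same ring, a 4.1-fold lower number from compound 1 to compound 2 (0.61 log units; beyond the scatter), was only modest. The aromatic group at this place can therefore move the number much further than the first pair indicated, and the move here is towards a lower number. No supporting evidence bears on why this exchange has so large an effect.

Within the data shown here, the single step changes both the substituent and its ring location, so the contributions of fluorine and of location cannot be separated; 4-fluorophenyl and 3-methylphenyl groups would divide the two. From the compounds shown here alone, whether the result extends to other 3-substituted rings, such as 3-chlorophenyl or 3-methoxyphenyl, or to unsubstituted phenyl also remains open.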